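Para-substituent change on the aryl methylidene acid series

The source may report more compounds than this note shows. Statements on the series, on what has been measured and on what is new or still open speak of the compounds shown alone.

Compound 1 `COc1ccc(/C=C2\CC[C@H]3C(C)(C)CCC[C@]3(C)[C@H]2CCC(C)CC(=O)O)cc1` in a functional assay on K562 cells (Homo sapiens) for cytotoxicity, read by MTT assay, with a stated time of 72 h (a higher number here means a weaker inhibitor, a lower number a stronger inhibitor), gives > 200000 nM, which is a limit of the assay and not a number.
Compound 2 `Cc1ccc(/C=C2\CC[C@H]3C(C)(C)CCC[C@]3(C)[C@H]2CCC(C)CC(=O)O)cc1` in this assay gives > 200000 nM, again a limit.
Compound 3 `CC(CC[C@H]1/C(=C/c2ccc(F)cc2)CC[C@H]2C(C)(C)CCC[C@]12C)CC(=O)O` in this assay gives > 200000 nM, also a limit.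

Compound 3 therefore stands only at a limit in this assay, as do the other two values shown; every measured compound sits at the limit of > 200000 nM in this assay, at which 3 of the 3 values shown sit, and none of the three is separated from another.

Compound 4 `CC(CC[C@H]1/C(=C/c2ccc(Br)cc2)CC[C@H]2C(C)(C)CCC[C@]12C)CC(=O)O` is not yet measured. It differs from compound 3 by bromo in place of fluoro on an aromatic carbon.

Going by the values given here, the steps that bear on this exchange of the para group are a step that the two limits leave unreadable from compound 1 to compound 2, a step that the two limits leave unreadable from compound 1 to compound 3 and a step that the two limits leave unreadable from compound 2 to compound 3. None of them can be read in size or direction, since both ends of each step are limits. Within the series there is no measured case in which changing the group on that aromatic carbon moved a value off the limit, and nothing indicates that bromo would behave otherwise.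

The expected step from compound 3 to compound 4 is thus a step that the limit leaves unreadable from compound 3 to compound 4, which is to say no readable change. For compound 4 in this assay the estimate is 300000 nM, within a range of 100000 nM to 1000000 nM, with a strong likelihood that only a limit is reported again.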

Compound 4, half-maximal inhibitory concentration: > 200000 nM
Compound 4: only a limit was reported; the forecaster's own chance of this, stated with the estimate: 85%; the middle value does not contradict the limit.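

In this assay compound 4 gives > 200000 nM, a limit and not a number, and no step joining compound 4 to compound 1, compound 2 or compound 3 can be read: the limit of > 200000 nM in this assay, at which 4 of the 4 values shown sit.

On these data alone, whether any group on that aromatic carbon of the shared core would bring a value off the limit in this assay stays open.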